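Swapping One Aryl Group on a Growth Inhibitor

The source may report more compounds than this note shows. Statements on the series, on what has been measured and on what is new or still open speak of the compounds shown alone.

In a functional assay on PC-3 cells (Homo sapiens) (on this read-out higher numbers stand for weaker inhibition of growth and lower numbers for stronger inhibition of growth), compound 1 (`O=S(=O)(/C=C/c1ccc(Br)cc1)Cc1ccc(Nc2ncnc3ccccc23)cc1`) gives 42000 nM. Compound 2 (`O=S(=O)(/C=C/c1ccc(Cl)c(Cl)c1)Cc1ccc(Nc2ncnc3ccc(Br)cc23)cc1`) gives 11000 nM, the lower of the two numbers, and so the stronger inhibition of growth. Compound 3 (`O=S(=O)(/C=C/c1ccc(Br)cc1)Cc1ccc(Nc2ncnc3ccc(Br)cc23)cc1`) has not yet been measured. It carries 4-bromophenyl in place of 3,4-dichlorophenyl on a double-bonded chain carbon bound to a double-bonded chain carbon. Going by the values given here, no measured pair shows this swap alone, so no change beyond the scatter is expected in this assay, perhaps a slightly higher number. The expected step is a 1.3-fold higher number from compound 2 to compound 3 (0.10 log units; within the scatter). Compound 3 is estimated at 14000 nM, within a range of 6000 nM to 32000 nM.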

Compound 3, concentration for 50% growth inhibition: 34000 nM
Beside the measured number, compound 3's estimate is 2.4-fold (0.39 log units) below it; measured number outside the range, above it.
By their numbers in this assay, from the lowest: compound 2; then compounds 3 and 1 (each within the scatter of the next).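

On the double-bonded chain, 4-bromophenyl in place of 3,4-dichlorophenyl gives a 3.1-fold higher number from compound 2 to compound 3 (0.49 log units; beyond the scatter) in this assay, so this aryl position responds to the swap. Bromo in place of hydrogen on an aromatic carbon gives only a 1.2-fold lower number from compound 1 to compound 3 (0.09 log units; within the scatter), a change that cannot be told from the scatter. Nothing measured here explains why the aryl swap shifts the number.

Still open, from the compounds shown here alone, is whether one chlorine alone on the phenyl would match 3,4-dichlorophenyl. Going by these compounds, how an amine or a carboxylic acid on that phenyl, or a longer chain in place of the ethenyl link, would read also remains unknown.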